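Trimming the cyclohexyl side chain of compound 2

A few compounds are considered here, and "the series" means these few. Any claim that something is new, unique, unknown or untested is made for them only; others in the source may bear on it.

Values in a functional assay on ACHN cells (Homo sapiens) for antiproliferative activity, read by sulforhodamine B assay; a lower number here means a stronger inhibitor of growth, a higher number a weaker inhibitor of growth:
- compound 1 `CC(C)(C)CCOc1cccc(O)c1C(=O)/C=C/c1ccc(O)cc1`: 3140 nM
- compound 2 `O=C(/C=C/c1ccc(O)cc1)c1c(O)cccc1OCCC1CCCCC1`: > 30000 nM, a limit of the assay
- compound 3 `O=C(/C=C/c1ccc(O)cc1)c1c(O)cccc1OCC1CCCCC1`: not yet measured

Compound 2 stands at the limit of > 30000 nM in this assay, at which 1 of the 2 values shown sits. It therefore has a limit and not a number. Compound 3 carries cyclohexyl in place of cyclohexylmethyl on a saturated chain carbon bound to an oxygen on an aromatic ring. Going by the values given here, one measured step bears on this side chain: an at least 9.5-fold higher number from compound 1 to compound 2 (0.98 log units; beyond the scatter), beyond the scatter, with cyclohexyl in place of tert-butyl. Among the compounds with values here, no measured step changes the chain length itself. Since that step shows how far a change in this chain can move this assay, a move to a lower number is expected, though compound 3 could also stay at the limit. The expected change is an at least 3.3-fold lower number from compound 2 to compound 3 (0.52 log units; beyond the scatter). For compound 3 the estimated value is 9000 nM, with an expected range of 2500 nM to 30000 nM.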

Compound 3, concentration for 50% growth inhibition: > 30000 nM
Compound 3: no number, only a limit; the forecaster's own chance of this, stated with the estimate: 35%; at least 3.3-fold (0.52 log units) between middle value and limit.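

In this assay, compound 3 gives > 30000 nM, which is a limit of the assay and not a number. The step between compound 2 and compound 3 cannot be read, and this follows from where their values sit: the limit of > 30000 nM in this assay, at which 2 of the 3 values shown sit. With cyclohexylmethyl on the chain, the result is still an at least 9.5-fold higher number from compound 1 to compound 3 (0.98 log units; beyond the scatter), so the shorter of the two cyclohexyl-bearing chains also fails to give a measurable value.

The compounds shown leave open whether any cyclohexyl-bearing chain can reach a measurable number in this assay, and how much of the value of compound 1 depends on its tert-butyl end. A cyclopentylmethyl chain, or an amine at the end of the chain, would bear on both questions.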